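The source may report more compounds than this note shows. Statements on the series, on what has been measured and on what is new or still open speak of the compounds shown alone.

Measured so far in a physicochemical assay for solubility, measured as kinetic solubility; on this read-out lower numbers stand for lower solubility and higher numbers for higher solubility:
compound 1 `Cc1cc(C)c(CN2CCc3c(Cl)cc([C@@H](CO)[C@@H]4CCOC4)c(Cl)c3C2=O)c(=O)[nH]1`: 537000 nM
compound 2 `CCOC(c1cc(Cl)c2c(c1Cl)C(=O)N(Cc1c(C)cc(C)[nH]c1=O)CC2)C1CS(=O)(=O)C1`: 453000 nM; 446000 nM (2 entries)
compound 3 `COC(C)c1cc(Cl)c2c(c1Cl)C(=O)N(Cc1c(C)cc(C)[nH]c1=O)CC2`: 49000 nM; 55300 nM (2 entries)

Compound 1, at 537000 nM, stands on a level with compound 2, whose repeat entries agree closely (the several entries of compound 2 in this assay, 453000 nM; 446000 nM (2 entries)). Compound 3 reads far lower, and its repeat entries also agree (the several entries of compound 3 in this assay, 49000 nM; 55300 nM (2 entries)). Compound 1 therefore belongs to the upper pair of the three measured compounds.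

The next compound is compound 4 `Cc1cc(C)c(CN2CCc3c(Cl)cc([C@@H](CO)[C@H]4CCCO4)c(Cl)c3C2=O)c(=O)[nH]1`, which has the same atoms as compound 1, joined differently: oxolan-2-yl in place of oxolan-3-yl on a saturated chain carbon bound to an aromatic carbon and a saturated chain carbon. The change places oxolan-2-yl in place of oxolan-3-yl on a saturated chain carbon bound to an aromatic carbon and a saturated chain carbon, and the rest of the structure stays as it is.

For the measured compounds named here, no measured pair isolates this swap. The expectation therefore starts from compound 1 at 537000 nM, and no change beyond the usual scatter is expected in this assay, in either direction. The estimated step is a 1.1-fold lower number from compound 1 to compound 4 (0.06 log units; within the scatter). The estimated value for compound 4 is 470000 nM, with an expected range of 220000 nM to 800000 nM.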

Compound 4, solubility: 576000 nM
Beside the measured number, compound 4's estimate is 1.2-fold (0.09 log units) below it, within the range that was stated.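

For the compounds shown here, the swap of oxolan-3-yl for oxolan-2-yl on a saturated chain carbon bound to an aromatic carbon and a saturated chain carbon gives a 1.1-fold higher number from compound 1 to compound 4 (0.03 log units; within the scatter) in this assay and forms the first pair that differs in one place. Going by these compounds alone, at this position, the read-out therefore does not separate the two ring attachments, a point the earlier compounds could not address. No measurement shown gives a cause for this flat step.

As far as these compounds go, whether an amine or a carboxylic acid in place of the oxolane ring would move the read-out beyond the scatter remains open, as only these two ring attachments are compared. From the compounds shown here alone, this swap is also seen only once, on the core of compound 1, so whether the flat step holds on another core remains unknown.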